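Replacing the Isobutyl Group of Compound 1 with an Aryl Ether

The source may report more compounds than this note shows. Statements on the series, on what has been measured and on what is new or still open speak of the compounds shown alone.

Measured compounds:
compound 1 `CC(C)Cc1ccc2c(NCCCNCc3ccco3)ccnc2c1`: 23 10^-6 cm/s
compound 2 `COc1ccc(F)cc1CNCCCNc1ccnc2cc(Oc3ccc(F)cc3)ccc12`: 317 10^-6 cm/s
compound 3 `COc1cccc(CNCCCNc2ccnc3cc(Cc4ccc(F)cc4)ccc23)c1O`: 23 10^-6 cm/s

These three compounds were tested in an ADME assay for permeability, using PAMPA, with a stated time of 30 min, at pH 7.4; on this read-out higher numbers stand for higher permeability and lower numbers for lower permeability. In this assay compound 1 gives 23 10^-6 cm/s, and compound 3 gives 23 10^-6 cm/s, so the two stand level, the lowest pair of the three. Compound 2 gives 317 10^-6 cm/s, a number well beyond the scatter above compound 1, which shows that much higher permeability is reachable within this set.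

The next compound, compound 4 `COc1ccccc1Oc1ccc2c(NCCCNCc3ccco3)ccnc2c1`, has not yet been measured. It differs from compound 1 in one place: 2-methoxyphenoxy in place of isobutyl on an aromatic carbon. Among the measured compounds shown here, no measured pair here reports exactly this change, so its size can only be guessed.

Because compound 2 gives 317 10^-6 cm/s while compound 1 gives 23 10^-6 cm/s, a rise seems more likely than a fall for compound 4, though its extent is uncertain. Compound 4 is therefore expected to show 90 10^-6 cm/s in this assay, within a range from 25 10^-6 cm/s to 320 10^-6 cm/s. This estimate corresponds to an expected step of a 3.9-fold higher number from compound 1 to compound 4 (0.59 log units; beyond the scatter), which lies beyond the scatter.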

Compound 4, apparent permeability: 317 10^-6 cm/s
Compound 4: the middle estimate sits 3.5-fold (0.55 log units) below what was measured; the range from low to high includes it.
By their numbers in this assay, from the lowest: compounds 1 and 3 (each within the scatter of the next); then compounds 2 and 4 (each within the scatter of the next).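

In this assay, among the compounds shown here, placing 2-methoxyphenoxy in place of isobutyl on this aromatic carbon gives a 14-fold higher number from compound 1 to compound 4 (1.14 log units; beyond the scatter), the first direct reading of a single change at this position. The step shows that, with the rest of compound 1 held fixed, this one place can move the read-out well beyond the scatter. The swap brings in more heavy atoms, a six-membered aromatic ring and two hydrogen-bond acceptors all at once, and nothing available explains which of these features matters.

A single pair cannot separate the contributions of the ether oxygen, the methoxy group and the added ring. Plain phenoxy, a simple methoxy, an amine or a carboxylic acid on the same carbon would show how far the step depends on each part and whether other groups at this position behave alike.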